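Bromo to nitro on a quinazoline-derived amide series

The source may hold more compounds than are shown below. What is called first, only, known or untested is meant among the compounds shown, and "the series" means these compounds.

Measured so far:
compound 1 `O=C(CSc1nc(Nc2ccccc2)c2ccccc2n1)Nc1cccc(Br)c1` — 9620 nM
compound 2 `O=C(CSc1nc(Nc2ccccc2)c2ccccc2n1)Nc1cccc([N+](=O)[O-])c1` — 28100 nM
compound 3 `C=CC(=O)Nc1cccc(NC(=O)CSc2nc(Nc3cccc(Br)c3)c3ccccc3n2)c1` — 11900 nM

Of the compounds shown here, three have been tested in a functional assay on MGC-803 cells (Homo sapiens) for inhibition, read by MTT assay, with a stated time of 72 h; on this read-out lower numbers stand for stronger inhibition and higher numbers for weaker inhibition. Compound 1 gives 9620 nM, and compound 2 gives 28100 nM; the change between them, (nitro in place of bromo on an aromatic carbon), is a step of a 2.9-fold higher number from compound 1 to compound 2 (0.47 log units; beyond the scatter). Compound 3 gives 11900 nM, a number close to that of compound 1 and within the usual scatter of it; the difference between the cores of compound 1 and compound 3 is not broken down here.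

Compound 4 `C=CC(=O)Nc1cccc(NC(=O)CSc2nc(Nc3cccc([N+](=O)[O-])c3)c3ccccc3n2)c1` has not yet been tested. It differs from compound 3 by nitro in place of bromo on an aromatic carbon, the same kind of change that took compound 1 to compound 2, placed on an aromatic carbon of a six-membered aromatic ring of carbon only, meta to a large group. The expectation for compound 4 rests on that one earlier step and on the value of compound 3, 11900 nM, so it is held loosely. In this assay compound 4 is expected to give about 30000 nM, between 14000 nM and 65000 nM, which means an estimated step of a 2.5-fold higher number from compound 3 to compound 4 (0.40 log units; beyond the scatter).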

Compound 4, half-maximal inhibitory concentration: > 50000 nM
Compound 4: no number, only a limit; the forecaster's own chance of this, stated with the estimate: 12%; at least 1.6-fold (0.22 log units) between middle value and limit.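

Compound 4 gives no number in this assay, only a limit of the assay, > 50000 nM. On the core of compound 3, nitro in place of bromo on an aromatic carbon gives an at least 4.2-fold higher number from compound 3 to compound 4 (0.62 log units; beyond the scatter), so the change points the same way on both cores and lies beyond the scatter on each. This shows that the loss of inhibition seen on the core of compound 1 carries over to the second core in direction, but it does not show whether the size of the step carries over, and two pairs give no rule for further cores: the same change on two cores in this assay, a 2.9-fold higher number (0.47 log units; beyond the scatter) from compound 1 to compound 2 and an at least 4.2-fold higher number (0.62 log units; beyond the scatter) from compound 3 to compound 4; the limit leaves it open whether they differ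

The compounds shown leave open how an amine, a nitrile or a methoxy group would compare with bromo and nitro on this aromatic carbon. They also leave open whether the same change would take the same direction on a third core, for instance one with a longer chain in place of the present link to the amide.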